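The source may report more compounds than this note shows. Statements on the series, on what has been measured and on what is new or still open speak of the compounds shown alone.

Measured so far in an assay on HEK293 cells for displacement of a labelled ligand from Melanocortin receptor 4 (Homo sapiens); on this read-out lower numbers stand for stronger inhibition and higher numbers for weaker inhibition:
compound 1 `CC(C)C[C@H](N)c1cc(C(F)(F)F)ccc1N1CCN(C(=O)CC(C)C(=O)c2ccc(Cl)cc2)CC1` gives 1100 nM
compound 2 `CC(C)C[C@H](N)c1cc(C(F)(F)F)ccc1N1CCN(C(=O)COc2cccc3ccccc23)CC1` gives 2600 nM

Compound 2 stands at the higher of the two numbers in this assay; its nearest neighbour is compound 1, reached by a 2.4-fold higher number from compound 1 to compound 2 (0.37 log units; beyond the scatter), a modest step that lies beyond the scatter.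

Compound 3 `CC(C)C[C@H](N)c1cc(C(F)(F)F)ccc1N1CCN(C(=O)CCC(=O)c2ccc(Cl)cc2)CC1` is not yet measured. Relative to compound 2 the change is ((4-chlorophenyl)carbonyl)methyl in place of (naphthalen-1-yl)oxy on a saturated chain carbon bound to a carbonyl carbon. Among the compounds with values here, the one measured step that bears on it is a 2.4-fold higher number from compound 1 to compound 2 (0.37 log units; beyond the scatter), in which the same (naphthalen-1-yl)oxy group entered at the same place in exchange for a closely related ((4-chlorophenyl)carbonyl)-bearing chain. The step from compound 2 to compound 3 largely undoes that exchange, so a modest lowering of the number, of roughly the size seen there, is expected rather than no change.

Compound 3 is therefore estimated at 1300 nM, between 600 nM and 3000 nM, corresponding to an expected step of a 2.0-fold lower number from compound 2 to compound 3 (0.30 log units; within the scatter).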

Compound 3, inhibition constant: 820 nM
Estimate against measurement, compound 3: 1.6-fold (0.20 log units) above, within the range that was stated.
By their numbers in this assay, from the lowest: compounds 3 and 1 (each within the scatter of the next); then compound 2.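

In this assay, ((4-chlorophenyl)carbonyl)methyl in place of (naphthalen-1-yl)oxy gives a 3.2-fold lower number from compound 2 to compound 3 (0.50 log units; beyond the scatter) and shows that the advantage of the (4-chlorophenyl)carbonyl chain over the naphthalenyl ether does not depend on the methyl carried by the earlier chain. Hydrogen in place of that methyl gives a 1.3-fold lower number from compound 1 to compound 3 (0.13 log units; within the scatter) and so leaves the read-out unresolved from the methyl-bearing chain at this place. No supporting data bear on the reason for either step.

The compounds shown leave open whether the carbonyl or the chlorine of this chain contributes on its own, as an unsubstituted phenyl ketone or a plain 4-chlorophenyl chain would test. Also open, on these data alone, is how a longer chain, an amine or a carboxylic acid would read at this place.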